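Working notes: the step from compound 3 to compound 4

This account rests on a few compounds, and the source may have more. Where it says the series, first, only, none or still open, it means among the compounds named here.

In a functional assay on FL5.12 cells (Mus musculus) for cytotoxicity, read by flow cytometry and propidium iodide staining, with a stated time of 48 h (a lower number here means a stronger inhibitor, a higher number a weaker inhibitor), compound 1 (`CCCCCCCCc1ccc(C(=O)C[C@@H]2CCCN2)cc1`) stands at 2500 nM and compound 2 (`CCCCCCCCc1ccc(C(C[C@@H]2CCCN2)OC)cc1`) at 3000 nM while compound 3 (`CCCCCCCCc1ccc(C(=O)C[C@H]2C[C@H](CO)CN2)cc1`) stands at 2000 nM on the same read-out. Compound 3 lies within the scatter of both compound 1 and compound 2, so it holds no separate place among the three.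

Compound 4 (`CCCCCCCCc1ccc(C(=O)CC[C@@H]2C[C@@H](O)CN2)cc1`) has the same atoms as compound 3, joined differently. The change is a group of 7 heavy atoms (5 carbon, 1 nitrogen, 1 oxygen; one five-membered non-aromatic ring with 1 hetero atom) in place of a group of 7 heavy atoms (5 carbon, 1 nitrogen, 1 oxygen; one five-membered non-aromatic ring with 1 hetero atom), on a saturated chain carbon bound to a carbonyl carbon and the entering group is named (4-hydroxypyrrolidin-2-yl)methyl in this series.

Among the measured compounds shown here, one measured step bears on it, at the same kind of place, on a saturated chain carbon bound to a carbonyl carbon. That step is a 1.3-fold lower number from compound 1 to compound 3 (0.10 log units; within the scatter) and it is small. For the measured compounds named here, no measured compound carries the entering group, so this evidence is indirect. Compound 2 changes another part of the molecule and says little about this exchange. No step beyond the scatter is therefore expected in this assay in either direction. The expected step is a 1.3-fold higher number from compound 3 to compound 4 (0.10 log units; within the scatter) on this estimate. The estimate for compound 4 is 2500 nM with an expected range from 1200 nM to 5500 nM as its bounds.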

Compound 4, half-maximal inhibitory concentration: 2100 nM
Beside the measured number, compound 4's estimate is 1.2-fold (0.08 log units) above it; the range from low to high includes it.
By their numbers in this assay, from the lowest: compounds 3, 4, 1 and 2 (each within the scatter of the next).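

Compound 4 adds a second exchange at the same place, on a saturated chain carbon bound to a carbonyl carbon, and this one keeps the atoms and joins them differently: a 1.1-fold higher number from compound 3 to compound 4 (0.02 log units; within the scatter) in this assay. Set against the parent group, (4-hydroxypyrrolidin-2-yl)methyl in place of pyrrolidin-2-yl gives a 1.2-fold lower number from compound 1 to compound 4 (0.08 log units; within the scatter), so the read-out separates neither exchange, and compounds 1, 3 and 4 form a set of three groups at this place that lie within the scatter of one another. Compounds 3 and 4 also show that this read-out does not distinguish how these atoms are joined within the group, a point that compound 1 and compound 3 alone could not address, and no measurement shown bears on why these groups go unseparated.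

On these data alone, it remains open whether an open-chain amine in place of pyrrolidin-2-yl, or a carboxylic acid on the group at this place, would give a step beyond the scatter. As far as these compounds go, it is also open whether the same flat picture would hold for these groups on a shared core carrying a longer chain.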